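Taking the fluoro off compound 3

The source may report more compounds than this note shows. Statements on the series, on what has been measured and on what is new or still open speak of the compounds shown alone.

Compound 1 `Cc1cc(C)c(S(=O)(=O)N2CCC(N3CCC(c4ccccc4)CC3)CC2)c(C)c1`: > 5000 nM (a limit)
Compound 2 `Cc1cc(C)c(S(=O)(=O)N2CCC(N3CCC(Cc4ccc(F)cc4)CC3)CC2)c(C)c1`: > 5000 nM (a limit)
Compound 3 `Cc1cc(C)c(S(=O)(=O)N2CCC(N3CCC(Cc4ccccc4F)CC3)CC2)c(C)c1`: > 5000 nM (a limit)

In an ADME assay on HCT-116 cells (Homo sapiens) for cytotoxicity, read by CellTiter-Glo, with a stated time of 72 h (on this read-out lower numbers stand for stronger inhibition and higher numbers for weaker inhibition), compound 3 stands at > 5000 nM, which is a limit and not a number. Among the measured compounds shown here, the whole series so far rests on (the limit of > 5000 nM in this assay, at which 3 of the 3 values shown sit). Compound 4 `Cc1cc(C)c(S(=O)(=O)N2CCC(N3CCC(Cc4ccccc4)CC3)CC2)c(C)c1` differs from compound 3 by one change: hydrogen in place of fluoro on an aromatic carbon. It has hydrogen in place of fluoro on an aromatic carbon, ortho to a large group, so that 2-fluorobenzyl becomes benzyl. For the measured compounds named here, three measured steps bear on this change. The closest is a step that the two limits leave unreadable from compound 2 to compound 3, which concerns the same benzyl group. The other two are a step that the two limits leave unreadable from compound 1 to compound 2 and a step that the two limits leave unreadable from compound 1 to compound 3. None of them gives a size, so none of them points in a direction, and no step beyond the scatter is expected in this assay. The assay will most likely report only a limit again. The expected step is a step that the limit leaves unreadable from compound 3 to compound 4. Compound 4 is estimated at about 7000 nM, with an expected range from 3000 nM to 20000 nM.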

Compound 4, half-maximal inhibitory concentration: > 5000 nM
Compound 4 ended at the assay's limit; the forecaster's own chance of this, stated with the estimate: 85%; the middle value lies beyond the limit too.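

Among the compounds shown here, no step to compound 4 from compound 1, compound 2 or compound 3 can be read, because all four compounds rest on the same limit: the limit of > 5000 nM in this assay, at which 4 of the 4 values shown sit. The compounds shown leave open how large any of their values is, and whether exchanging fluoro for hydrogen changes anything.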